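Swapping fluoro for hydroxy at a chain end

The compounds below may be only part of what the source reports. "The series", "measured", "known", "first", "only" and "open" are said of these compounds alone.

Compound 3 `O=c1n(Cc2cc3cnccc3n2CCCCF)c2cnccc2n1C1CC1` was tested in an ADME assay on HeLa cells (Homo sapiens) for cytotoxicity, read by ATP content, with a stated time of 3 days; a lower number here means that less compound is tolerated, a higher number that more compound is tolerated. In this assay compound 3 gives > 50000 nM, which is a limit of the assay rather than a number. Compound 1 `N=C(CCCn1c(Cn2c(=O)n(C3CC3)c3ccncc32)cc2cc(Cl)ccc21)NO` gives > 50000 nM in this assay, also a limit. Compound 2 `O=c1n(Cc2cc3cnccc3n2CCCC(F)(F)F)c2cnccc2n1C1CC1` gives > 50000 nM in this assay, again a limit. The step that the two limits leave unreadable from compound 2 to compound 3 cannot be read; both of its ends are limits. All three measured values share (the limit of > 50000 nM in this assay, at which 3 of the 3 values shown sit).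

Compound 4 `O=c1n(Cc2cc3cnccc3n2CCCCO)c2cnccc2n1C1CC1` has not yet been measured. It differs from compound 3 by hydroxy in place of fluoro on a saturated chain carbon, four bonds along the chain from an aromatic nitrogen. For the measured compounds named here, no measured step involves a hydroxy group, so the change itself has no measured counterpart here; the only guide is that compound 3 and its two relatives all sit at the limit. Compound 4 is expected to sit there as well, so the expected step reads a number no higher from compound 3 to compound 4 (the limit leaves the size open). For compound 4 in this assay the estimate is 50000 nM, with a range from 20000 nM to 120000 nM.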

Compound 4, half-maximal cytotoxic concentration: > 100000 nM
Compound 4: a limit, no number; the forecaster's own chance of this, stated with the estimate: 85%; middle value at least 2.0-fold (0.30 log units) away from the limit.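

For the compounds shown here, compound 4, like compound 2 and compound 3, stands at a limit of the assay rather than a number, and no step between them can be read. The compounds shown leave open whether hydroxy in place of fluoro changes the half-maximal cytotoxic concentration at all.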